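Carbazole-free coumarin pyrazolines: nitrophenyl step in paw edema

The source may hold more compounds than are shown below. What is called first, only, known or untested is meant among the compounds shown, and "the series" means these compounds.

Compound 1 `O=c1oc2ccccc2cc1C1=NN(c2ccccc2)[C@@H](c2ccc(Cl)cc2)C1` and compound 2 `CN(C)c1ccc([C@H]2CC(c3cc4ccccc4oc3=O)=NN2c2ccccc2)cc1` share one core and differ only in the group on the saturated ring carbon. In a functional assay on the whole organism (strain albino) for inhibition, with Rattus norvegicus as the target, read by paw edema, with stated times of 1 h and 4 h, at a dose of 200 mg/kg by the oral route (on this read-out lower numbers stand for less inhibition and higher numbers for more inhibition at the one dose given (going by the name of the read-out)), compound 1 gives 64.7%, while in this assay compound 2 gives 40.1%. For the measured compounds named here, the one measured step is a number 24.6 percentage points lower from compound 1 to compound 2 (beyond the scatter), so compound 2 stands lowest of the two numbers, with compound 1 as its nearest neighbour and the gap beyond the scatter.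

Compound 3 `O=c1oc2ccccc2cc1C1=NN(c2ccccc2)[C@@H](c2cccc([N+](=O)[O-])c2)C1` is not yet measured in this assay. It differs from compound 2 by 3-nitrophenyl in place of 4-(dimethylamino)phenyl on a saturated ring carbon. Going by the values given here, no step involving a 3-nitrophenyl group has been measured here; the only step that bears on this position is the chloro-to-dimethylamino change from compound 1 to compound 2, which was modest in size and downward. The change to compound 3 touches the same position, so a step of comparable size is plausible, and the expectation is that it runs upward, partly reversing the drop seen for compound 2.

The expected step for compound 3 is therefore a number 14.9 percentage points higher from compound 2 to compound 3 (beyond the scatter), and the estimated inhibition for compound 3 is 55%, within a range from 40% to 70%.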

Compound 3, a percentage reported as inhibition, in the whole organism at one dose (the size of the read-out at that dose, not a potency): 31.2%
For compound 3 the middle estimate is 23.8 percentage points above the measured one, and the stated range ends above it.
By their numbers in this assay, from the lowest: compounds 3 and 2 (each within the scatter of the next); then compound 1.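

In this assay, 3-nitrophenyl in place of 4-(dimethylamino)phenyl on the saturated ring carbon gives a number 8.9 percentage points lower from compound 2 to compound 3 (within the scatter) and so does not separate these two groups at this position. Set against 4-chlorophenyl, the same group gives a number 33.5 percentage points lower from compound 1 to compound 3 (beyond the scatter) and this is a large step, so the drop first seen with compound 2 is not particular to 4-(dimethylamino)phenyl, and compound 1 is the highest of the three, beyond the scatter from both others. No measurement at hand accounts for why the two replacements land within the scatter of each other or why 4-chlorophenyl stands apart from them.

The change from compound 1 to compound 3 alters both the group on the aromatic ring and where it sits on that ring, so the compounds shown cannot say which of the two goes with the large step. The unsubstituted phenyl group, 3-chlorophenyl and 4-nitrophenyl on the same carbon would each pull these apart and show whether chloro itself is what sets compound 1 apart.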